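The source may hold more compounds than are shown below. What is called first, only, known or untested is meant among the compounds shown, and "the series" means these compounds.

Measured compounds:
- Compound 1 `CCNC(=O)N1CCN(C(=S)SCc2cn(Cc3ccc(Cl)cc3)nn2)CC1`: in a functional assay on EC9706 cells (Homo sapiens) for cytotoxicity, read by MTT assay, with a stated time of 72 h (a lower number here means a stronger inhibitor, a higher number a weaker inhibitor), compound 1 gives > 128000 nM, which is a limit of the assay and not a number.
- Compound 2 `COc1ccc(Cn2cc(CSC(=S)N3CCN(C(N)=O)CC3)nn2)cc1`: in this assay compound 2 gives > 128000 nM, again a limit and not a number.

Compound 2 therefore stands at the limit of > 128000 nM in this assay, at which 2 of the 2 values shown sit; both values shown sit there, so no order between the two can be read. Compound 3 `CCNC(=O)N1CCN(C(=S)SCc2cn(Cc3ccc(OC)cc3)nn2)CC1` differs from compound 2 by ethyl in place of hydrogen on an amide-type nitrogen. For the measured compounds named here, no measured step carries this change, and with both neighbours at the limit no direction in this assay can be set; no step beyond the scatter is expected. Compound 3 is expected at 200000 nM, within 100000 nM to 500000 nM, and most likely reported only as a limit. The expected shift is a step that the limit leaves unreadable from compound 2 to compound 3.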

Compound 3, half-maximal inhibitory concentration: > 128000 nM
Compound 3 was reported as a limit (the forecaster's own chance of this, stated with the estimate: 85%); the middle value does not contradict the limit.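

No new step can be read between compound 3 and compound 1 or compound 2, since all three values are limits and not numbers: the limit of > 128000 nM in this assay, at which 3 of the 3 values shown sit.

The compounds shown leave open whether ethyl in place of hydrogen, or methoxy in place of chloro, changes anything in this assay.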